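The source may hold more compounds than are shown below. What is called first, only, known or untested is meant among the compounds shown, and "the series" means these compounds.

Measured so far:
Compound 1, `Fc1ccc(/C=N/c2sc3c(c2-c2nc4ccccc4s2)CCC3)cc1`: 302 ug/mL
Compound 2, `C(=C/c1ccccc1)\C=N\c1sc2c(c1-c1nc3ccccc3s1)CCC2`: 215 ug/mL
Compound 3, `Fc1ccc(/C=N/c2sc3c(c2-c2nc4ccccc4s2)CCCC3)cc1`: 324 ug/mL

All three were tested in an ADME assay on HepG2 cells (Homo sapiens) for cytotoxicity, read by MTT assay, with a stated time of 72 h; on this read-out higher numbers stand for lower toxicity in this test and lower numbers for higher toxicity in this test. The three numbers sit close together: compound 3 gives 324 ug/mL, and its gaps to compound 1 and to compound 2 are both within the usual scatter, so none of the three stands apart from the others.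

Compound 4, `O=[N+]([O-])c1ccc(/C=N/c2sc3c(c2-c2nc4ccccc4s2)CCCC3)cc1`, has not yet been measured. It differs from compound 3 by nitro in place of fluoro on an aromatic carbon; read one bond further out, this is 4-fluorophenyl to 4-nitrophenyl.

For the measured compounds named here, only one measured step touches the same part of the molecule: a 1.4-fold lower number from compound 1 to compound 2 (0.15 log units; within the scatter), where the whole 4-fluorophenyl group was exchanged for 2-phenylethenyl without moving the number beyond the scatter. Going by the values given here, no measured step exchanges one substituent on that phenyl ring for another, so there is nothing that points to a shift in either direction for a nitro group.

On that basis the step from compound 3 to compound 4 is expected to stay within the scatter, a 1.2-fold lower number from compound 3 to compound 4 (0.06 log units; within the scatter). Compound 4 is therefore estimated at 280 ug/mL in this assay, with a range from 140 ug/mL to 560 ug/mL.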

Compound 4, half-maximal cytotoxic concentration: 454 ug/mL
Estimate against measurement, compound 4: 1.6-fold (0.21 log units) below, within the range that was stated.
By their numbers in this assay, from the lowest: compounds 2, 1, 3 and 4 (each within the scatter of the next, the first and the last beyond it).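

In this assay, for the compounds shown here, nitro in place of fluoro on an aromatic carbon, para to a large group, gives the first measured exchange of one substituent on this phenyl ring for another (a 1.4-fold higher number from compound 3 to compound 4 (0.15 log units; within the scatter)). The position therefore accepts a group of three heavy atoms and two hydrogen-bond acceptors where fluoro has one heavy atom and no acceptors, and the number stays within the usual scatter. Nothing measured alongside these compounds speaks to what lies behind this result.

Fluoro and nitro are the only two substituents compared on this ring, so it remains open whether an amine, a carboxylic acid or a longer chain at the same place would also leave the number within the scatter of compound 3. Also open, from the compounds shown here alone, is whether nitro in place of fluoro on the core of compound 1 would give a step of similar size, as the exchange has been read on the core of compound 3 alone.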